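Tolyl Amine Replaces Piperidine on the Shared Core

This account rests on a few compounds, and the source may have more. Where it says the series, first, only, none or still open, it means among the compounds named here.

Compound 1 `Cc1cc(NC(C)C)nc(SCc2nc3ccccc3[nH]2)n1` in a functional assay on MCF7 cells (Homo sapiens) for cytotoxicity, read by MTT assay, with a stated time of 72 h (a higher number here means a weaker inhibitor, a lower number a stronger inhibitor), gives > 100000 nM, a limit of the assay.
Compound 2 `Cc1cc(N2CCCCC2)nc(SCc2nc3ccccc3[nH]2)n1` in this assay gives > 100000 nM, also a limit.
Compound 3 `Cc1cc(Nc2ccc(Br)cc2)nc(SCc2nc3ccccc3[nH]2)n1` in this assay gives 38000 nM.

From the compounds shown here alone, compound 2 sits at the limit, so its true value is unknown, as is the step that the two limits leave unreadable from compound 1 to compound 2. Two of the three values share this limit (the limit of > 100000 nM in this assay, at which 2 of the 3 values shown sit). Compound 4 `Cc1ccc(Nc2cc(C)nc(SCc3nc4ccccc4[nH]3)n2)cc1` changes compound 2 in one place: (4-methylphenyl)amino in place of piperidin-1-yl on an aromatic carbon. The nearest measured guide is an at least 2.6-fold lower number from compound 2 to compound 3 (0.42 log units; beyond the scatter), and an at least 2.6-fold lower number from compound 1 to compound 3 (0.42 log units; beyond the scatter) points the same way. An aryl amine in place of the piperidine is therefore expected to give a modest drop, an at least 2.5-fold lower number from compound 2 to compound 4 (0.39 log units; beyond the scatter), in this assay. Compound 4 is estimated at 40000 nM, within 15000 nM to 100000 nM.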

Compound 4, half-maximal inhibitory concentration: 56500 nM
Compound 4: the middle estimate sits 1.4-fold (0.15 log units) below what was measured; measured number inside the range.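

Methyl in place of bromo on the aryl ring leaves the number within the scatter, a 1.5-fold higher number from compound 3 to compound 4 (0.17 log units; within the scatter), so compounds 3 and 4 read alike in this assay. Compound 4 also gives a second aryl amine with a measurable value, but the steps from the two aliphatic amines are only floors, an at least 1.7-fold lower number from compound 2 to compound 4 (0.24 log units; that floor lies within the scatter) and an at least 1.7-fold lower number from compound 1 to compound 4 (0.24 log units; that floor lies within the scatter). From the compounds shown here alone, neither floor clears the scatter, and their true sizes stay unknown: the limit of > 100000 nM in this assay, at which 2 of the 4 values shown sit.

Going by these compounds, how a methoxy group or a carboxylic acid in place of the methyl would read remains open.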